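The compounds below may be only part of what the source reports. "The series", "measured", "known", "first", "only" and "open" are said of these compounds alone.

Compound 2 `CC(=O)CCCON1C(=O)[C@@H](NC(=O)OCCCCC2CCCCC2)[C@@H]1C` gives 75 nM in an assay on HEK293 cells for inhibition of N-acylethanolamine-hydrolyzing acid amidase (Homo sapiens), read by fluorescence, with stated times of 10 min and 50 min (on this read-out lower numbers stand for stronger inhibition and higher numbers for weaker inhibition), the lowest of the two numbers; compound 1 `CSCCCON1C(=O)[C@@H](NC(=O)OCCCCC2CCCCC2)[C@@H]1C` gives 167 nM in this assay, and the step of a 2.2-fold lower number from compound 1 to compound 2 (0.35 log units; beyond the scatter) is the only measured one. Compound 3 `C[C@H]1[C@H](NC(=O)OCCCCC2CCCCC2)C(=O)N1OCCCCC1CCCCC1` differs from compound 2 by cyclohexylmethyl in place of acetyl on a saturated chain carbon, three bonds along the chain from an oxygen on an unsaturated carbon. Going by the values given here, no measured step covers cyclohexylmethyl; the acetyl acceptor that accompanied the gain in compound 2 is removed, and compound 1, which also lacks such an acceptor, gives 167 nM in this assay. A modest rise is therefore expected, a 1.7-fold higher number from compound 2 to compound 3 (0.24 log units; within the scatter). Compound 3 is estimated at 130 nM, with a range of 40 nM to 400 nM.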

Compound 3, half-maximal inhibitory concentration: 3470 nM
The estimate for compound 3 lay 27-fold (1.43 log units) below the measured number, and the stated range ends below it.
By their numbers in this assay, from the lowest: compound 2; then compound 1; then compound 3.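

In this assay, this position proves far more sensitive than the first pair suggested: cyclohexylmethyl in place of acetyl gives a 46-fold higher number from compound 2 to compound 3 (1.67 log units; beyond the scatter), and cyclohexylmethyl in place of methylsulfanyl gives a 21-fold higher number from compound 1 to compound 3 (1.32 log units; beyond the scatter). Both steps are large, whereas the step between the two ring-free groups is modest, and only compound 3 carries a ring on this chain. Nothing available accounts for the loss.

On these data alone, whether the ring itself or the greater number of heavy atoms goes with the loss stays open. A longer straight alkyl chain, a phenyl ring or an amine at this place would help separate these readings.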